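The compounds below may be only part of what the source reports. "The series", "measured", "known", "first", "only" and "open" are said of these compounds alone.

Working notes on the series. In a functional assay on MDA-MB-231 cells (Homo sapiens) for antiproliferative activity, read by MTT assay, with a stated time of 24 h (on this read-out lower numbers stand for stronger inhibition and higher numbers for weaker inhibition), compound 1 `CCCCc1oc2ccccc2c1C(=O)c1ccc(OCC(=O)NC(C)C)cc1` reads > 50000 nM, which is a limit and not a number. Among the measured compounds shown here, compound 2 `CCCCc1oc2ccccc2c1C(=O)c1ccc(OCC(=O)N[C@H](C)c2ccccc2)cc1` gives 39000 nM, the only actual number in this assay so far.

Compound 3 `CCCCNC(=O)CCCOc1ccc(C(=O)c2c(CCCC)oc3ccccc23)cc1` is the next to read. Its change from compound 2 is 2-(butylcarbamoyl)ethyl in place of (1-phenylethyl)carbamoyl on a saturated chain carbon bound to an oxygen on an aromatic ring, so the entering group has no ring.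

For the measured compounds named here, one measured step bears on this: an at least 1.2-fold lower number from compound 1 to compound 2 (0.10 log units; that floor lies within the scatter), with 1-phenylethyl in place of isopropyl on an amide-type nitrogen. Going by these compounds, its true size stays open, since one end is the limit of > 50000 nM in this assay, at which 1 of the 2 values shown sits. This is thin support, but compound 1 also lacks a ring on its amide nitrogen, so a weak result is expected again. The expected step is a 1.3-fold higher number from compound 2 to compound 3 (0.11 log units; within the scatter), with a shift to a higher number more likely than one to a lower number, and a limit reading is quite possible. For compound 3 the estimate is 50000 nM, with an expected range of 20000 nM to 120000 nM.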

Compound 3, half-maximal inhibitory concentration: 38100 nM
Beside the measured number, compound 3's estimate is 1.3-fold (0.12 log units) above it; low and high end bracket the measured number.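

In this assay, the change to 2-(butylcarbamoyl)ethyl gives a 1.0-fold lower number from compound 2 to compound 3 (0.01 log units; within the scatter), so on this saturated chain carbon bound to an oxygen on an aromatic ring, the two groups cannot be told apart. A measured number therefore does not depend on the six-membered aromatic ring of (1-phenylethyl)carbamoyl, which compounds 1 and 2 alone could not show. The comparison of an at least 1.3-fold lower number from compound 1 to compound 3 (0.11 log units; that floor lies within the scatter) gives only a floor, and its true size stays open: the limit of > 50000 nM in this assay, at which 1 of the 3 values shown sits.

The entering group differs in both its chain and its nitrogen substituent, so the contribution of each stays unresolved. Also open, going by these compounds, is whether a carboxylic acid or a tertiary amine at this position, or a longer chain on the amide nitrogen, would move the number beyond the scatter.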